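The compounds below may be only part of what the source reports. "The series", "measured", "known", "first", "only" and "open" are said of these compounds alone.

Compound 1 `Nc1nc(OCC(F)(F)F)c2ncn(/C=C3/CC3(CO)CO)c2n1` sits at the limit > 300000 nM in an ADME assay on HFF cells (Homo sapiens) for cytotoxicity, with a stated time of 8 days (a lower number here means that less compound is tolerated, a higher number that more compound is tolerated), and this is a limit of the assay rather than a number.
Compound 2 `CCOc1nc(N)nc2c1ncn2/C=C1/CC1(CO)CO` sits at the limit > 300000 nM in this assay.
Compound 3 `Nc1nc(NC2CC2)c2ncn(/C=C3/CC3(CO)CO)c2n1` sits at the limit > 300000 nM in this assay.

Compound 2 therefore stands only at a limit, and the two other values shown are limits as well, as the limit of > 300000 nM in this assay, at which 3 of the 3 values shown sit, records. Within the data shown here, the step that the two limits leave unreadable from compound 2 to compound 3 is the only measured step that starts from compound 2, and it is unreadable; the steps a step that the two limits leave unreadable from compound 1 to compound 2 and a step that the two limits leave unreadable from compound 1 to compound 3 are equally unreadable. Compound 4 `Nc1nc(N2CCCC2)c2ncn(/C=C3/CC3(CO)CO)c2n1` differs from compound 2 in this way: pyrrolidin-1-yl in place of ethoxy on an aromatic carbon. Among the measured compounds shown here, no measured step gives a size for any change at this position, so the only expectation the data support is that compound 4 is estimated to sit at the limit again, with the step of a number no higher from compound 2 to compound 4 (the limit leaves the size open) expected to show nothing beyond the scatter. Compound 4 is estimated at 300000 nM, between 100000 nM and 600000 nM, in this assay.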

Compound 4, half-maximal cytotoxic concentration: > 300000 nM
Compound 4 ended at the assay's limit; the forecaster's own chance of this, stated with the estimate: 80%; the middle value lies on the limit itself.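

Among these compounds, compound 4 gives > 300000 nM in this assay, which is a limit of the assay, so no step from compound 1, compound 2 or compound 3 to compound 4 can be read. All four compounds rest at one ceiling: the limit of > 300000 nM in this assay, at which 4 of the 4 values shown sit.

The compounds shown leave open how far any of these groups on the aromatic carbon would shift the tolerated concentration.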